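Methyl on the fused five-membered ring: expected effect

The compounds below may be only part of what the source reports. "The series", "measured", "known", "first", "only" and "open" are said of these compounds alone.

Measured so far:
compound 1 `CCOC(=O)C1=C(C)NC(C)=C(C(=O)OCC)C1c1c(-c2ccccc2F)nc2sccn12` gives 980 nM
compound 2 `CCOC(=O)C1=C(C)NC(C)=C(C(=O)OCC)C1c1c(-c2ccc(F)cc2)nc2sccn12` gives 1650 nM

In an ADME assay on Right cardiac atrium (Cavia porcellus) (a lower number here means that less compound is needed, a higher number that more compound is needed for the effect), compound 2 stands with the highest of the two numbers, and its nearest neighbour is compound 1, with a 1.7-fold higher number from compound 1 to compound 2 (0.23 log units; within the scatter). Compound 3 `CCOC(=O)C1=C(C)NC(C)=C(C(=O)OCC)C1c1c(-c2ccc(F)cc2)nc2sc(C)cn12` differs from compound 2 by methyl in place of hydrogen on an aromatic carbon, placed on the five-membered aromatic ring of the fused system. Among the measured compounds shown here, no measured step touches that ring; the only known step concerns the fluorophenyl and was within the scatter. With nothing to point either way, the expected step of no change at the digits printed from compound 2 to compound 3 (within the scatter) is none beyond the scatter. Compound 3 is therefore estimated at 1650 nM, with a range from 600 nM to 4500 nM.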

Compound 3, half-maximal effective concentration: 23 nM
For compound 3 the middle estimate is 72-fold (1.86 log units) above the measured one; the measured number lies below the stated range.
By their numbers in this assay, from the lowest: compound 3; then compounds 1 and 2 (each within the scatter of the next).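

A single added carbon can matter far more here than moving the fluorine on the phenyl ring did. In this assay, methyl in place of hydrogen, next to the ring sulfur, gives a 72-fold lower number from compound 2 to compound 3 (1.86 log units; beyond the scatter) for this one change, so this position on the five-membered aromatic ring is highly sensitive. Nothing measured here says why the number falls so far. On these data alone, whether an ethyl group, a longer chain or a chlorine atom at this carbon would do the same stays open. So does whether methyl has a similar effect alongside the 2-fluorophenyl group of compound 1.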